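A Second Chlorine on the Pendant Ring

This account rests on a few compounds, and the source may have more. Where it says the series, first, only, none or still open, it means among the compounds named here.

Compound 1 `COc1cccc(/C=C2\CCC/C(=C\c3ccc(Cl)cc3)C2=O)c1OC` was tested in a functional assay on MCF7 cells (Homo sapiens) for cytotoxicity, read by MTT assay, with a stated time of 72 h (on this read-out higher numbers stand for weaker inhibition and lower numbers for stronger inhibition), where compound 1 gives 10300 nM. Compound 2 `COc1cccc(/C=C2\CCC/C(=C\c3ccccc3Br)C2=O)c1OC` gives 9700 nM in that assay; the step of a 1.1-fold lower number from compound 1 to compound 2 (0.03 log units; within the scatter) stays within the scatter, so compound 1 holds the larger of the two numbers only by a margin that means nothing. Compound 3 `COc1cccc(/C=C2\CCC/C(=C\c3ccc(O)cc3)C2=O)c1OC` reaches only a limit of the assay, > 20000 nM. The change from compound 1 to compound 4 `COc1cccc(/C=C2\CCC/C(=C\c3cc(Cl)cc(Cl)c3)C2=O)c1OC` is 3,5-dichlorophenyl in place of 4-chlorophenyl on a double-bonded chain carbon bound to a double-bonded ring carbon. Among the compounds with values here, the one measured step that also swaps halogens on the pendant ring, a 1.1-fold lower number from compound 1 to compound 2 (0.03 log units; within the scatter), stayed within the scatter, so no step beyond the scatter is expected for a 1.3-fold lower number from compound 1 to compound 4 (0.11 log units; within the scatter). Compound 4 is therefore estimated at 8000 nM, with a range from 3500 nM to 20000 nM.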

Compound 4, half-maximal inhibitory concentration: 4300 nM
The estimate for compound 4 lay 1.9-fold (0.27 log units) above the measured number; the range from low to high includes it.
By their numbers in this assay, from the lowest: compound 4; then compounds 2 and 1 (each within the scatter of the next). At a limit, above all of these: compound 3.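

In this assay, the 3,5-dichlorophenyl group of compound 4 is the only change shown at this double-bonded chain carbon that lowers the number beyond the scatter: a 2.4-fold lower number from compound 1 to compound 4 (0.38 log units; beyond the scatter) and a 2.3-fold lower number from compound 2 to compound 4 (0.35 log units; beyond the scatter). The earlier swap between single-halogen rings, 4-chlorophenyl and 2-bromophenyl, stayed within the scatter. Compound 3 stands at a limit and not a number, so an at least 4.6-fold lower number from compound 3 to compound 4 (0.66 log units; beyond the scatter) is only a floor: the limit of > 20000 nM in this assay, at which 1 of the 4 values shown sits.

Still open, going by these compounds, is whether the gain follows from the second chlorine or from where the two chlorines sit, and what an amine or a carboxylic acid would do on this pendant ring.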